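Fluoro to Iodo on the Same Aromatic Carbon

A few compounds are considered here, and "the series" means these few. Any claim that something is new, unique, unknown or untested is made for them only; others in the source may bear on it.

Measured in a functional assay on HL-60 cells (Homo sapiens) for antiproliferative activity, with a stated time of 24 h; on this read-out higher numbers stand for weaker inhibition and lower numbers for stronger inhibition:
- compound 1, `NC(=O)c1c(NC(=O)c2ccccc2Cl)sc2c1CCN(Cc1c(Cl)cccc1Cl)C2`, gives 4850 nM
- compound 2, `NC(=O)c1c(NC(=O)c2ccccc2Cl)sc2c1CCN(C(=S)Nc1ccccc1)C2`, gives 5940 nM
- compound 3, `NC(=O)c1c(NC(=O)c2ccccc2Cl)sc2c1CCN(C(=S)Nc1ccccc1F)C2`, gives 4970 nM

Compound 3 holds the second highest of the three numbers, but all three lie within the scatter of one another: a 1.0-fold higher number from compound 1 to compound 3 (0.01 log units; within the scatter) and a 1.2-fold lower number from compound 2 to compound 3 (0.08 log units; within the scatter), so no ordering among them can be read.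

Compound 4, `NC(=O)c1c(NC(=O)c2ccccc2Cl)sc2c1CCN(C(=S)Nc1ccccc1I)C2`, differs from compound 3 by iodo in place of fluoro on an aromatic carbon. Among the measured compounds shown here, no measured step swaps one halogen for another. The nearest comparison is a 1.2-fold lower number from compound 2 to compound 3 (0.08 log units; within the scatter), which placed a halogen on the same aromatic carbon without a change beyond the scatter. The larger rebuilds of the group on the ring amine nitrogen, a 1.2-fold higher number from compound 1 to compound 2 (0.09 log units; within the scatter) and a 1.0-fold higher number from compound 1 to compound 3 (0.01 log units; within the scatter), also stayed within the scatter. On this basis the step of a 1.0-fold higher number from compound 3 to compound 4 (0.00 log units; within the scatter) is expected to stay within the scatter. Compound 4 is therefore estimated at 5000 nM in this assay, with a likely range from 2000 nM to 12000 nM.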

Compound 4, half-maximal inhibitory concentration: 4430 nM
Compound 4: middle estimate off by 1.1-fold (0.05 log units), on the high side; low and high end bracket the measured number.
By their numbers in this assay, from the lowest: compounds 4, 1, 3 and 2 (each within the scatter of the next).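

In this assay, this aromatic carbon, ortho to a large group, has now carried two different halogens, and exchanging them gives a 1.1-fold lower number from compound 3 to compound 4 (0.05 log units; within the scatter) so fluoro and iodo cannot be told apart here. The result also extends the flat picture to the largest halogen: iodo in place of hydrogen gives a 1.3-fold lower number from compound 2 to compound 4 (0.13 log units; within the scatter) and the full rebuild of the group on the ring amine nitrogen gives a 1.1-fold lower number from compound 1 to compound 4 (0.04 log units; within the scatter) so no change in this series has yet moved the number beyond the scatter. No other measurement is available to explain this flat result.

On these data alone, it remains open whether a non-halogen group on this carbon, such as an amine or a carboxylic acid, would behave the same way. Also open, as far as these compounds go, is whether iodo or fluoro on another carbon of this ring would leave the number unchanged.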